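The source may hold more compounds than are shown below. What is called first, only, known or untested is meant among the compounds shown, and "the series" means these compounds.

Measured compounds:
- compound 1, `N#Cc1c(-c2ccccc2)nc2c(c(-c3ccccc3)nn2-c2ccccc2)c1-c1ccc(N2CCCCC2)cc1`: 30900 nM
- compound 2, `c1ccc(-c2ccnc3c2c(-c2ccccc2)nn3-c2ccccc2)cc1`: 3210 nM
- compound 3, `Clc1ccc(-c2ccnc3c2c(-c2ccccc2)nn3-c2ccccc2)cc1`: 61100 nM

All three were tested in a functional assay on HepG2 cells (Homo sapiens) for inhibition, read by MTT assay, with a stated time of 48 h; a lower number here means a stronger inhibitor, a higher number a weaker inhibitor. Compound 2 gives 3210 nM, while compound 3 gives 61100 nM. The two differ in one place only: chloro in place of hydrogen on an aromatic carbon. That single change produced a 19-fold higher number from compound 2 to compound 3 (1.28 log units; beyond the scatter), so the chloro-bearing compound 3 is the weaker inhibitor of the pair by a wide margin.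

Compound 1 carries a different core; the difference between the core of compound 1 and that of compound 2 is not broken down here. In this assay compound 1 gives 30900 nM, which lies close to the value of compound 3 and well away from that of compound 2.

Compound 4, `N#Cc1c(-c2ccc(Cl)cc2)nc2c(c(-c3ccccc3)nn2-c2ccccc2)c1-c1ccc(N2CCCCC2)cc1`, has not yet been measured. It is related to compound 1 by exactly the change that turned compound 2 into compound 3: chloro in place of hydrogen on an aromatic carbon. The place of the change is described in the same words for both pairs. It is the same change, made on a different core.

Compound 4 is therefore expected to be a weaker inhibitor than compound 1, with a step of about a 4.9-fold higher number from compound 1 to compound 4 (0.69 log units; beyond the scatter), resting on the size of the earlier step from compound 2 to compound 3 and on the already weak value of compound 1. The estimate for compound 4 is 150000 nM, expected to fall between 35000 nM and 600000 nM, with a fair chance that this assay reports only a limit.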

Compound 4, half-maximal inhibitory concentration: 3210 nM
Compound 4: the middle estimate sits 47-fold (1.67 log units) above what was measured; the whole stated range lies above it.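

In this assay, the change from phenyl to 4-chlorophenyl on the core of compound 1 gave a 9.6-fold lower number from compound 1 to compound 4 (0.98 log units; beyond the scatter), so compound 4 is the stronger inhibitor of this pair, whereas the chloro made compound 3 the weaker inhibitor of the earlier pair. Set side by side, the same change moved the number in opposite directions, and the gap between the two steps is larger than repeated measurement would explain: the same change on two cores in this assay, a 19-fold higher number (1.28 log units; beyond the scatter) from compound 2 to compound 3 and a 9.6-fold lower number (0.98 log units; beyond the scatter) from compound 1 to compound 4, 180-fold (2.26 log units) apart, beyond the scatter of two such steps. Going by these compounds alone, this shows that neither the direction nor the size of the chloro step carries over from one core to the other, but it does not show why the two differ, as each core gives only one pair, and the structures do not separate the effect of the core from that of which phenyl ring takes the chloro.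

The compounds shown leave open whether a fluoro or a methoxy group in place of the chloro would move the number the same way on each core. They also leave open which part of the core of compound 1, such as its nitrile, goes with the reversal.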